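This account rests on a few compounds, and the source may have more. Where it says the series, first, only, none or still open, it means among the compounds named here.

Among the compounds with values here, compound 1 `CC1CCCN1c1ccc2cc(NC(=O)CCc3ccc(C(F)(F)F)cc3)ccc2n1` is the stronger of the two compounds measured so far: in a functional assay on HEK293 cells for activation of melanin-concentrating hormone receptor 1 (Rattus norvegicus), read by inositol phosphate accumulation (a lower number here means that less compound is needed, a higher number that more compound is needed for the effect), compound 1 gives 270 nM, while compound 2 `CCN(CC)c1ccc2cc(NC(=O)CCc3ccc(C(F)(F)F)cc3)ccc2n1` gives 830 nM, and the step of a 3.1-fold higher number from compound 1 to compound 2 (0.49 log units; beyond the scatter) swapped the 2-methylpyrrolidin-1-yl for diethylamino. Compound 3 `O=C(CCc1ccc(C(F)(F)F)cc1)Nc1ccc2nc(N3CC4CCC3C4)ccc2c1` differs from compound 1 by a group of 7 heavy atoms (6 carbon, 1 nitrogen; one five-membered non-aromatic ring of carbon only, one five-membered non-aromatic ring with 1 hetero atom) in place of a group of 6 heavy atoms (5 carbon, 1 nitrogen; one five-membered non-aromatic ring with 1 hetero atom), on an aromatic carbon. Within the data shown here, the only measured step, from compound 1 to compound 2, removed the five-membered ring altogether; here a ring with one hetero atom remains and gains one carbon, so the step of a 1.1-fold higher number from compound 1 to compound 3 (0.05 log units; within the scatter) is expected to stay within the scatter. Compound 3 is therefore estimated at 300 nM, in a range from 100 nM to 900 nM.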

Compound 3, half-maximal effective concentration: 150 nM
The estimate for compound 3 lay 2.0-fold (0.30 log units) above the measured number, and the stated range covers the measured number.
By their numbers in this assay, from the lowest: compounds 3 and 1 (each within the scatter of the next); then compound 2.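

At this aromatic carbon, next to the ring nitrogen, a group with a second five-membered ring is accepted: a 1.8-fold lower number from compound 1 to compound 3 (0.26 log units; within the scatter) in this assay, so compounds 1 and 3 cannot be ranked. Set against the ring-free diethylamino group, the same group gives a clearer gap, a 5.5-fold lower number from compound 2 to compound 3 (0.74 log units; beyond the scatter), and so both compounds with a ring here give lower numbers than compound 2. Nothing available explains these differences. The compounds shown leave open how a six-membered ring such as piperidin-1-yl, or a morpholin-4-yl with its added ring oxygen, would behave at this carbon.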